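A few compounds are considered here, and "the series" means these few. Any claim that something is new, unique, unknown or untested is made for them only; others in the source may bear on it.

Three measured compounds share one core and differ only in the group attached to the double-bonded nitrogen. Compound 1 `N/N=C1\C(=O)Nc2ccc(S(=O)(=O)N3CCOCC3)cc21` carries an amino group there, compound 2 `O=C1Nc2ccc(S(=O)(=O)N3CCOCC3)cc2/C1=N/NS(=O)(=O)c1ccccc1` a (phenylsulfonyl)amino group, and compound 3 `O=C1Nc2ccc(S(=O)(=O)N3CCOCC3)cc2/C1=N/c1ccc(O)cc1` a 4-hydroxyphenyl group. In a functional assay on HepG2 cells (Homo sapiens) for cytotoxicity, read by sulforhodamine B assay, with a stated time of 24 h (on this read-out lower numbers stand for stronger inhibition and higher numbers for weaker inhibition), compound 1 gives 32400 nM, compound 2 gives 23900 nM and compound 3 gives 10400 nM. The step of a 1.4-fold lower number from compound 1 to compound 2 (0.13 log units; within the scatter) falls within the scatter, so compounds 1 and 2 cannot be separated on these numbers. The steps of a 3.1-fold lower number from compound 1 to compound 3 (0.49 log units; beyond the scatter) and a 2.3-fold lower number from compound 2 to compound 3 (0.36 log units; beyond the scatter) are modest but beyond the scatter, so compound 3 stands lowest of the three, meaning it inhibits the cells most strongly.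

Compound 4 `O=C1Nc2ccc(S(=O)(=O)N3CCOCC3)cc2/C1=N/c1ccc(C(=O)O)cc1` keeps the 4-hydroxyphenyl framework of compound 3 but changes one group on it: carboxy in place of hydroxy on an aromatic carbon. Among the measured compounds shown here, none of the measured steps bears directly on this change, since all of them alter the group on the double-bonded nitrogen rather than a substituent on the aromatic ring. With no guide from the measured pairs, the expectation is a step about the size of the scatter or smaller. Compound 4 is therefore estimated at 13000 nM, with a range from 5000 nM to 35000 nM. The expected step of a 1.3-fold higher number from compound 3 to compound 4 (0.10 log units; within the scatter) is small and may lie within the scatter.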

Compound 4, half-maximal inhibitory concentration: 23100 nM
Compound 4: middle estimate off by 1.8-fold (0.25 log units), on the low side; the measured number falls inside the stated range.
By their numbers in this assay, from the lowest: compound 3; then compounds 4, 2 and 1 (each within the scatter of the next).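

In this assay, among the compounds shown here, the first change to a substituent on the aromatic ring, rather than to the whole group on the double-bonded nitrogen, shows that this ring position affects the result: carboxy in place of hydroxy produces a 2.2-fold higher number from compound 3 to compound 4 (0.35 log units; beyond the scatter) and removes the lead that compound 3 held. The new compound also cannot be separated from the two earlier ones, as the comparisons show a 1.0-fold lower number from compound 2 to compound 4 (0.01 log units; within the scatter) and a 1.4-fold lower number from compound 1 to compound 4 (0.15 log units; within the scatter) so an aromatic ring on that nitrogen does not by itself set a compound apart, and what the ring carries counts as well. No measurement shown here explains why the hydroxy and carboxy compounds differ.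

On these data alone, with only these two ring substituents in hand, it remains open whether the higher number belongs to carboxy in particular or would also appear with other groups at the same place, such as a methoxy group, an amine or a methyl ester. An unsubstituted phenyl group would show whether hydroxy lowers the number or carboxy raises it, a distinction that this single pair cannot make.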